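Cytotoxicity notes: amide nitrogen substituent series

This account rests on a few compounds, and the source may have more. Where it says the series, first, only, none or still open, it means among the compounds named here.

Measured compounds:
compound 1 `CCOc1ccc(NC(=O)c2cccc(/C=C3\CC(=O)N(c4ccccc4)C3=O)c2)cc1`: 91500 nM
compound 2 `COc1ccc(NC(=O)c2cccc(/C=C3\CC(=O)N(c4ccccc4)C3=O)c2)cc1`: > 100000 nM (a limit of the assay)
compound 3 `Cc1cccc(NC(=O)c2cccc(/C=C3\CC(=O)N(c4ccccc4)C3=O)c2)c1`: > 100000 nM (a limit of the assay)

In an ADME assay on SW480 cells (Homo sapiens) for cytotoxicity, read by MTT assay, with a stated time of 72 h (on this read-out higher numbers stand for weaker inhibition and lower numbers for stronger inhibition), compound 1 gives 91500 nM. Compound 2 reaches only a limit of the assay, > 100000 nM. Compound 3 likewise reaches only a limit of the assay, > 100000 nM, so compound 3 stands at the weak end of what this assay records, as described by the limit of > 100000 nM in this assay, at which 2 of the 3 values shown sit. Of the measured steps, an at least 1.0-fold higher number from compound 1 to compound 2 (0.03 log units; that floor lies within the scatter) and an at least 1.0-fold higher number from compound 1 to compound 3 (0.03 log units; that floor lies within the scatter) are both floors that lie within the scatter, and a step that the two limits leave unreadable from compound 2 to compound 3 cannot be read.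

Compound 4 `O=C(NCc1ccccc1)c1cccc(/C=C2\CC(=O)N(c3ccccc3)C2=O)c1` differs from compound 3 in one place: benzyl in place of 3-methylphenyl on an amide-type nitrogen. The measured steps bearing on this nitrogen, from compound 1 to compound 2 and from compound 1 to compound 3, gave no shift beyond the scatter, and none tests a benzyl group there. Compound 4 is therefore expected to show no step beyond the scatter, a number no higher from compound 3 to compound 4 (the limit leaves the size open). In this assay compound 4 is estimated at 100000 nM, expected between 30000 nM and 300000 nM, most likely again as a limit.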

Compound 4, half-maximal inhibitory concentration: > 100000 nM
Compound 4: a limit, no number; the forecaster's own chance of this, stated with the estimate: 60%; the middle value sits exactly at the limit.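

Compound 4 gives > 100000 nM in this assay, a limit of the assay. Benzyl has the same atoms as 3-methylphenyl, joined differently, and on the amide-type nitrogen this rearrangement still gives no readable value; the steps from compound 2 and from compound 3 to compound 4 cannot be read, and the one readable step is an at least 1.0-fold higher number from compound 1 to compound 4 (0.03 log units; that floor lies within the scatter). The series now gathers at the weak end of the assay's range: the limit of > 100000 nM in this assay, at which 3 of the 4 values shown sit.

The compounds shown leave open whether any group on this nitrogen brings the value clearly under the limit, for instance a benzyl bearing a carboxylic acid or a longer chain ending in an amine. They also leave open how far past the limit compound 2, compound 3 and compound 4 lie.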